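One Replacement on the Carbonyl Carbon of Compound 2

The source may report more compounds than this note shows. Statements on the series, on what has been measured and on what is new or still open speak of the compounds shown alone.

For the measured compounds named here, compound 2 `CCCSc1nc(Cl)c2c(n1)N(Cc1ccccc1)C(C(=O)OCC)N2` is one of two compounds measured in a functional assay on A549 cells (Homo sapiens) for antiproliferative activity, read by MTT assay, with a stated time of 72 h (a higher number here means a weaker inhibitor, a lower number a stronger inhibitor), where compound 2 gives 13800 nM. Compound 1 `CCCSc1nc(Cl)c2c(n1)N(CCNC(=O)OC(C)(C)C)C(C(=O)N1CCN(C)CC1)N2` gives 12400 nM in this assay, and the two values lie within the scatter of each other, so neither stands apart. Compound 3 `CCCSc1nc(Cl)c2c(n1)N(Cc1ccccc1)C(C(=O)NCCNC(=O)OC(C)(C)C)N2` has not yet been measured. It differs from compound 2 in one place: (2-((tert-butoxycarbonyl)amino)ethyl)amino in place of ethoxy on a carbonyl carbon. Compound 1 already carries a (2-((tert-butoxycarbonyl)amino)ethyl) group and its value sits close to that of compound 2. The expected step for compound 3 is therefore a 1.2-fold lower number from compound 2 to compound 3 (0.06 log units; within the scatter), nothing beyond the scatter. Compound 3 is estimated at 12000 nM, between 4000 nM and 36000 nM.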

Compound 3, half-maximal inhibitory concentration: 53200 nM
Compound 3: the middle estimate sits 4.4-fold (0.65 log units) below what was measured; the measured number lies above the stated range.
By their numbers in this assay, from the lowest: compounds 1 and 2 (each within the scatter of the next); then compound 3.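

On this carbonyl carbon the swap matters: in this assay, (2-((tert-butoxycarbonyl)amino)ethyl)amino in place of ethoxy gives a 3.9-fold higher number from compound 2 to compound 3 (0.59 log units; beyond the scatter), a modest step but one beyond the scatter. The two earlier compounds differ in more than one place, so they could not show that this single position responds to a change on its own. No available evidence accounts for this step.

Going by these compounds, it remains open whether the weaker number follows the amide link or the long tert-butoxycarbonyl chain. A simple ethylamino group or a free aminoethyl amine on the same carbon would separate the two.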